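Ethyl on a fluorinated, inactive series: working notes

This account rests on a few compounds, and the source may have more. Where it says the series, first, only, none or still open, it means among the compounds named here.

Measured in a functional assay on MDA-MB-231 cells (Homo sapiens) for antiproliferative activity, read by MTT assay, with a stated time of 72 h; on this read-out higher numbers stand for weaker inhibition and lower numbers for stronger inhibition:
- compound 1 `O=c1oc2cc(O)ccc2cc1-c1ccc(O)cc1`: > 100000 nM (a limit)
- compound 2 `O=c1oc2cc(O)ccc2cc1-c1ccc(O)c(F)c1`: > 100000 nM (a limit)

Compound 2 stands only at a limit, > 100000 nM, and has no numerical value. Compound 3 `CCc1c(-c2ccc(O)c(F)c2)c(=O)oc2cc(O)ccc12` differs from it by ethyl in place of hydrogen on an aromatic carbon, with the ethyl opposite the ring oxygen. Among the compounds with values here, the one measured step, a step that the two limits leave unreadable from compound 1 to compound 2, concerns a different change and gives no size to carry over. Within the data shown here, the only evidence is the limit of > 100000 nM in this assay, at which 2 of the 2 values shown sit. In this assay, at most a modest move toward stronger inhibition is expected, and a further limit is the likelier result. The expected step is an at least 1.4-fold lower number from compound 2 to compound 3 (0.15 log units; that floor lies within the scatter), a rough estimate. Compound 3 is estimated at 70000 nM, with an expected range of 20000 nM to 200000 nM.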

Compound 3, half-maximal inhibitory concentration: 48600 nM
Estimate against measurement, compound 3: 1.4-fold (0.16 log units) above, within the range that was stated.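

Ethyl opposite the ring oxygen gives the first readable change in this series in this assay, with an at least 2.0-fold lower number from compound 2 to compound 3 (0.31 log units; beyond the scatter). This position therefore responds to substitution, whereas the fluoro change left both compounds at limits. The size of the step is only a floor, as compound 2 holds a limit, > 100000 nM, and not a number.

On these data alone, whether a longer chain, such as propyl, would lower the number further at this position remains open. So does the outcome with an amine or a carboxylic acid there.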